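The compounds below may be only part of what the source reports. "The series", "measured", "known", "first", "only" and "open" are said of these compounds alone.

In an assay on cells for displacement of a labelled ligand from Orexin/Hypocretin receptor type 1 (Homo sapiens), read by scintillation counting, with stated times of 10 min and 90 min, tested at 10 uM (on this read-out higher numbers stand for more inhibition at the one concentration tested (going by the name of the read-out) and lower numbers for less inhibition), two compounds of this study have numbers. Compound 1, `O=C(O)c1ccc2c(C(=O)c3ccccc3)cc(C(=O)c3ccccc3)c-2cc1`, gives -10.4%. Compound 2, `COC(=O)Cc1ccc2ccc(C(=O)c3ccccc3)c-2cc1`, gives -37.7%, the lower of the two numbers, and its gap to compound 1 lies beyond the scatter. Compound 3, `COC(=O)Cc1ccc2c(C(=O)c3ccccc3)cc(C(=O)c3ccccc3)c-2cc1`, is not yet measured; it carries a benzoyl in place of hydrogen on an aromatic carbon relative to compound 2. For the measured compounds named here, no step between measured compounds is on record. With compound 1 at -10.4%, a modest upward step is expected, about a number 17.7 percentage points higher from compound 2 to compound 3 (beyond the scatter). Compound 3 is estimated at -20%, within -45% to 10%.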

Compound 3, a percentage reported as inhibition, at one concentration (the size of the read-out at that concentration, not a potency): -21.4%
Compound 3: the middle estimate sits 1.4 percentage points above what was measured; the range from low to high includes it.
By their numbers in this assay, from the lowest: compound 2; then compound 3; then compound 1.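

In this assay, a benzoyl in place of hydrogen on an aromatic carbon of the five-membered aromatic ring gives a number 16.3 percentage points higher from compound 2 to compound 3 (beyond the scatter), so a change at this position alone moves the number beyond the scatter. With that benzoyl present, (methoxycarbonyl)methyl in place of carboxy gives a number 11 percentage points lower from compound 1 to compound 3 (beyond the scatter), which isolates a second single change on the shared core. Nothing on record explains either step. The compounds shown leave open whether an amine or a longer chain at this aromatic carbon would give a different number.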